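Amide nitrogen substituent changes in the series

The compounds below may be only part of what the source reports. "The series", "measured", "known", "first", "only" and "open" are said of these compounds alone.

Compound 1 `CN1CCC(NC(=O)c2ccncc2Nc2cc(-c3ccc4ccn(C)c4c3)c3nccnc3c2)CC1=O`: 41 nM
Compound 2 `CN1CC(NC(=O)c2ccncc2Nc2cc(-c3ccc4ccn(C)c4c3)c3nccnc3c2)CCC1=O`: 116 nM

Among the measured compounds shown here, in an assay for inhibition of 6-phosphofructo-2-kinase/fructose-2,6-bisphosphatase 3 (Homo sapiens), read by ADP-Glo, with a stated time of 2 h (on this read-out higher numbers stand for weaker inhibition and lower numbers for stronger inhibition), compound 2 gives 116 nM, the higher of the two numbers; the step of a 2.8-fold higher number from compound 1 to compound 2 (0.45 log units; beyond the scatter) is the only measured change at this position. Compound 3 `Cn1ccc2ccc(-c3cc(Nc4cnccc4C(=O)NCC4COCCN4)cc4nccnc34)cc21` differs from compound 2 by (morpholin-3-yl)methyl in place of 1-methyl-6-oxopiperidin-3-yl on an amide-type nitrogen. For the measured compounds named here, that earlier step moved the same ring's oxo group and nitrogen and was modest; the present change exchanges the whole ring and adds a donor, which no measured pair covers. A step of similar modest size in either direction is expected, so compound 3 is expected to give 150 nM (range 45 nM to 500 nM), a step of a 1.3-fold higher number from compound 2 to compound 3 (0.11 log units; within the scatter).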

Compound 3, half-maximal inhibitory concentration: 33 nM
Compound 3: middle estimate off by 4.5-fold (0.66 log units), on the high side; measured number outside the range, below it.
By their numbers in this assay, from the lowest: compounds 3 and 1 (each within the scatter of the next); then compound 2.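

In this assay the change to (morpholin-3-yl)methyl on the amide-type nitrogen gives a 3.5-fold lower number from compound 2 to compound 3 (0.55 log units; beyond the scatter) and also a 1.2-fold lower number from compound 1 to compound 3 (0.09 log units; within the scatter) at this position. The oxo group of the two piperidinyl substituents is therefore not required here, and a substituent with a ring oxygen and a hydrogen-bond donor matches 1-methyl-2-oxopiperidin-4-yl within the scatter. No measurement available here accounts for this result. The ring oxygen, the ring nitrogen and the methyl link all differ at once, so their shares stay unseparated. Piperidin-3-ylmethyl or morpholin-3-yl on the same nitrogen would separate them.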